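Removing the Ether Methyl: Little Change Expected

The compounds below may be only part of what the source reports. "The series", "measured", "known", "first", "only" and "open" are said of these compounds alone.

Measured so far in an assay (Canis lupus familiaris) for binding affinity to platelet-activating factor receptor (Homo sapiens), read by radioligand binding; on this read-out higher numbers stand for weaker inhibition and lower numbers for stronger inhibition:
compound 1 `COc1cccc(-c2ccc(C(=O)N[C@H](C)CCCc3cccnc3)cc2)c1` gives 20 nM
compound 2 `COc1cccc(-c2ccc(C(=O)NCCCCc3cccnc3)cc2)c1` gives 280 nM

Among the measured compounds shown here, compound 2 stands at the higher of the two numbers so far; its only neighbour is compound 1, and the single measured step, a 14-fold higher number from compound 1 to compound 2 (1.15 log units; beyond the scatter), describes that gap. Compound 3 `O=C(NCCCCc1cccnc1)c1ccc(-c2cccc(O)c2)cc1` has not yet been measured. It differs from compound 2 by hydrogen in place of methyl on an oxygen on an aromatic ring. For the measured compounds named here, no measured step touches this part of the molecule: the step from compound 1 to compound 2 concerns a methyl on the saturated chain carbon bound to the amide-type nitrogen, not the methyl on the aromatic oxygen, so it does not bear on the change to compound 3. With nothing pointing in either direction, a step beyond the scatter is not expected. The expected value for compound 3 is therefore 280 nM, within a range of 90 nM to 900 nM, which means an expected step of no change at the digits printed from compound 2 to compound 3 (within the scatter).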

Compound 3, half-maximal inhibitory concentration: 300 nM
Compound 3: middle estimate off by 1.1-fold (0.03 log units), on the low side; the measured number falls inside the stated range.
By their numbers in this assay, from the lowest: compound 1; then compounds 2 and 3 (each within the scatter of the next).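

In this assay, going from 3-methoxyphenyl to 3-hydroxyphenyl gives a 1.1-fold higher number from compound 2 to compound 3 (0.03 log units; within the scatter) and is the first step shown at this position. On this evidence, the methyl on the oxygen on the aromatic ring can give way to hydrogen without moving the read-out beyond the scatter, at least in compound 2, which lacks the chain methyl of compound 1. Nothing at hand explains why this exchange leaves the number where it is.

From the compounds shown here alone, whether the same exchange would read alike on compound 1, with its chain methyl in place, remains open. Among the compounds shown here, also open is what an ethoxy group, an amine or a carboxylic acid would give in that place on the aromatic ring, since methoxy and hydroxy are the only two groups compared there so far.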